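Dropping a methoxy group from a compound at the limit

The compounds below may be only part of what the source reports. "The series", "measured", "known", "first", "only" and "open" are said of these compounds alone.

Measured compounds:
compound 1 `COc1ccccc1-c1ncnn1-c1cc(OC)c(OC)c(OC)c1` gives > 10000 nM
compound 2 `COc1cc(-c2ncnn2-c2ccc(Cl)cc2Cl)cc(OC)c1OC` gives > 10000 nM

In a functional assay on MCF7 cells (Homo sapiens) for antiproliferative activity, read by MTT assay, with a stated time of 72 h (on this read-out lower numbers stand for stronger inhibition and higher numbers for weaker inhibition), compound 1 gives > 10000 nM, which is a limit of the assay rather than a number. Compound 2 likewise gives only a limit, > 10000 nM. Among the compounds with values here, compound 1 thus stands at the edge of what this assay can report, and the only other value shown sits at the same edge (the limit of > 10000 nM in this assay, at which 2 of the 2 values shown sit).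

Compound 3 `COc1cc(-n2ncnc2-c2ccccc2)cc(OC)c1OC` differs from compound 1 in one place: hydrogen in place of methoxy on an aromatic carbon. Within the data shown here, no measured pair shows what such a change does here, so nothing in these data points toward a gain or a loss in potency. With both measured compounds sitting at the limit, the most likely outcome is that compound 3 also sits at or near that limit, and any expected step in this assay from compound 1 should be none beyond the scatter. The expected step that the limit leaves unreadable from compound 1 to compound 3 is therefore essentially flat. Compound 3 is estimated to give about 15000 nM in this assay, most likely between 3000 nM and 60000 nM.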

Compound 3, half-maximal inhibitory concentration: > 10000 nM
Compound 3: a limit, no number; the forecaster's own chance of this, stated with the estimate: 75%; the middle value does not contradict the limit.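

Compound 1 and compound 3 both end at a limit of the assay rather than a number, so no step between them can be read: the limit of > 10000 nM in this assay, at which 3 of the 3 values shown sit.

The compounds shown leave open whether hydrogen in place of methoxy changes potency at all, and how potent any of the three really is.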